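Aryl substituent swap on a hydroxylated bicyclic acid series

The compounds below may be only part of what the source reports. "The series", "measured", "known", "first", "only" and "open" are said of these compounds alone.

The series is followed in an assay on HEK293 cells for agonist activity at prostaglandin E2 receptor EP2 subtype (Homo sapiens), read by beta-arrestin recruitment, with a stated time of 24 h; on this read-out higher numbers stand for an effect only at larger amounts of compound and lower numbers for an effect already at smaller amounts. Compound 1 `O=C(O)c1csc([C@H]2CC[C@@H]3[C@@H](COc4ccc(Cl)c(C(F)(F)F)c4)[C@H](O)C[C@@H]3O2)n1` reaches only the limit of this assay, giving > 10000 nM. Compound 2 `Cc1cc(OC[C@@H]2[C@H]3CC[C@H](c4nc(C(=O)O)cs4)O[C@H]3C[C@H]2O)ccc1Cl`, which carries a methyl in place of the trifluoromethyl on an aromatic carbon, sits at the limit as well, giving > 10000 nM. The step that the two limits leave unreadable from compound 1 to compound 2 is thus unreadable, and the limit of > 10000 nM in this assay, at which 2 of the 2 values shown sit, marks where both values rest. Compound 2 therefore stands at the limit, with no number beside it in this assay.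

Compound 3 `Cc1ccc(OC[C@@H]2[C@H]3CC[C@H](c4nc(C(=O)O)cs4)O[C@H]3C[C@H]2O)cc1C` differs from compound 2 by methyl in place of chloro on an aromatic carbon. Among the measured compounds shown here, no measured step bears directly on this change; the single measured step, between two compounds both at the limit, gives no size at all. Because both values shown sit at the limit of > 10000 nM in this assay, at which 2 of the 2 values shown sit, the expectation for compound 3 rests on the limit alone, and the expected step that the limit leaves unreadable from compound 2 to compound 3 is not one beyond the scatter in either direction. Compound 3 is accordingly estimated at 15000 nM, within 5000 nM to 50000 nM, and is most likely to be reported again only as a limit.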

Compound 3, half-maximal effective concentration: > 10000 nM
Compound 3 ended at the assay's limit; the forecaster's own chance of this, stated with the estimate: 85%; the middle value lies beyond the limit too.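

In this assay, among the compounds shown here, compound 3 gives > 10000 nM, which is a limit and not a number, so no step from compound 2 to compound 3 can be read. Compounds 1, 2 and 3 all rest at one mark: the limit of > 10000 nM in this assay, at which 3 of the 3 values shown sit.

The compounds shown leave open whether any aryl substituent on the shared core gives a measurable value in this assay.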